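A few compounds are considered here, and "the series" means these few. Any claim that something is new, unique, unknown or untested is made for them only; others in the source may bear on it.

Compound 1 `CCOC(=O)c1sc(-c2cccc(NC(=O)c3cccc(F)c3)c2)nc1Nc1ccc(N2CCN(C)CC2)cc1`: 82.8%
Compound 2 `CN1CCN(c2ccc(Nc3nc(-c4cccc(NC(=O)c5ccc(C(F)(F)F)cc5)c4)sc3C(N)=O)cc2)CC1`: 91.9%
Compound 3 `CN1CCN(c2ccc(Nc3nc(-c4cccc(NC(=O)c5ccc(C(C)(C)C)cc5)c4)sc3C(N)=O)cc2)CC1`: 12.1%

In a functional assay on Raji cells (Homo sapiens) for antiproliferative activity, read by CCK-8 assay, with a stated time of 72 h, tested at 40 uM (a lower number here means less inhibition, a higher number more inhibition at the concentration tested (going by the name of the read-out)), compound 3 gives the lowest number of the three; compound 1 sits well above it and compound 2 highest of all, both gaps beyond the scatter. Within the data shown here, the one measured step that touches compound 3 is a number 79.8 percentage points lower from compound 2 to compound 3 (beyond the scatter), a large fall. Compound 4 `CN1CCN(c2ccc(Nc3nc(-c4cccc(NC(=O)c5cccc(F)c5)c4)sc3C(N)=O)cc2)CC1` removes that same group again: 3-fluorophenyl in place of 4-(tert-butyl)phenyl on a carbonyl carbon. Compound 1 carries the same 3-fluorophenyl on its carbonyl and differs from compound 4 only elsewhere; in this assay compound 1 gives 82.8%. Compound 4 is therefore expected to recover most of what was lost, a number 71.9 percentage points higher from compound 3 to compound 4 (beyond the scatter), with an estimated 84%, in the range 62% to 96%.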

Compound 4, a percentage reported as inhibition, at one concentration (the size of the read-out at that concentration, not a potency): 2.78%
The estimate for compound 4 lay 81.2 percentage points above the measured number; the measured number lies below the stated range.
By their numbers in this assay, from the lowest: compounds 4 and 3 (each within the scatter of the next); then compounds 1 and 2 (each within the scatter of the next).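

In this assay, 3-fluorophenyl in place of 4-(tert-butyl)phenyl on this carbonyl carbon gives a number 9.3 percentage points lower from compound 3 to compound 4 (within the scatter), so this change restores nothing while the amino group stays. The same group set against 4-(trifluoromethyl)phenyl gives a number 89.1 percentage points lower from compound 2 to compound 4 (beyond the scatter), and amino in place of ethoxy gives a number 80 percentage points lower from compound 1 to compound 4 (beyond the scatter), so what 3-fluorophenyl delivers depends on the group at that other carbonyl carbon. Nothing available here explains these falls. On these data alone, it remains open whether 4-(trifluoromethyl)phenyl holds its number with ethoxy, and how a carboxylic acid or a methylamino group would read at that carbonyl carbon.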